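Para-nitrobenzyl variant of a chromone triazole ether

This account rests on a few compounds, and the source may have more. Where it says the series, first, only, none or still open, it means among the compounds named here.

Compound 1 `Cc1cccc(Cn2cc(COc3ccc4c(=O)ccoc4c3)nn2)c1` is a chromone ether carrying a benzylic triazole. In a functional assay on A549 cells (Homo sapiens) for cytotoxicity, read by MTT assay, with a stated time of 48 h (on this read-out higher numbers stand for weaker inhibition and lower numbers for stronger inhibition), compound 1 gives 20300 nM, the higher of the two numbers available, though its nearest neighbour sits within the scatter. Compound 3 `O=c1ccoc2cc(OCc3cn(Cc4ccccc4F)nn3)ccc12` gives 10800 nM in this assay, so the step of a 1.9-fold lower number from compound 1 to compound 3 (0.27 log units; within the scatter) tells no real change. Compound 2 `O=c1ccoc2cc(OCc3cn(Cc4ccc(Cl)cc4)nn3)ccc12` reaches only the limit of this assay, > 100000 nM, and no number can be given for it. The step of an at least 4.9-fold higher number from compound 1 to compound 2 (0.69 log units; beyond the scatter) therefore marks a clear loss, as does an at least 9.2-fold lower number from compound 2 to compound 3 (0.96 log units; beyond the scatter) read the other way; both rest on (the limit of > 100000 nM in this assay, at which 1 of the 3 values shown sits).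

Compound 4 `O=c1ccoc2cc(OCc3cn(Cc4ccc([N+](=O)[O-])cc4)nn3)ccc12` is the next member. Relative to compound 1 the change is 4-nitrophenyl in place of 3-methylphenyl on a saturated chain carbon bound to an aromatic nitrogen. Among the compounds with values here, the only step with a substituent in the same ring position, from compound 1 to compound 2, went toward the limit, and no other measured step reports on a 4-nitrophenyl group. Compound 4 is thus expected to show a weaker result than compound 1, a step of a 2.5-fold higher number from compound 1 to compound 4 (0.39 log units; beyond the scatter), with a fair chance of reaching the limit. The estimate for compound 4 is 50000 nM, between 15000 nM and 150000 nM.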

Compound 4, half-maximal inhibitory concentration: > 100000 nM
Compound 4 ended at the assay's limit; the forecaster's own chance of this, stated with the estimate: 35%; middle value at least 2.0-fold (0.30 log units) away from the limit.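

Compound 4 is the second compound at the limit of this assay, so the loss seen with the 4-chlorophenyl group is not confined to that one group. The 4-nitrophenyl group gives an at least 4.9-fold higher number from compound 1 to compound 4 (0.69 log units; beyond the scatter) and an at least 9.2-fold higher number from compound 3 to compound 4 (0.96 log units; beyond the scatter), so among the compounds shown, both 4-substituted phenyl groups lie beyond the scatter of the 3-methylphenyl and 2-fluorophenyl compounds. The step from compound 2 to compound 4, nitro in place of chloro on an aromatic carbon, cannot be read, and the two groups cannot be ordered, since both compounds stand at the limit: the limit of > 100000 nM in this assay, at which 2 of the 4 values shown sit.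

From the compounds shown here alone, whether a 4-aminophenyl or 4-methoxyphenyl group would also reach the limit remains open. So does whether a 2-nitrophenyl or 3-chlorophenyl group would keep a readable number.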